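This account rests on a few compounds, and the source may have more. Where it says the series, first, only, none or still open, it means among the compounds named here.

Measured so far: compound 1, `CN1CCN(CCCC(=O)O[C@@H]2C[C@@H]3CC[C@@]2(C)C3(C)C)CC1`, gives 99200 nM in an ADME assay on HEK-293T cells (Homo sapiens) for cytotoxicity, read by MTT assay, with a stated time of 48 h; on this read-out higher numbers stand for lower toxicity in this test and lower numbers for higher toxicity in this test; compound 2, `CCN1CCN(CCCC(=O)O[C@@H]2C[C@@H]3CC[C@@]2(C)C3(C)C)CC1`, gives 131000 nM; compound 3, `CN1CCN(CCC(=O)N[C@@H]2C[C@H]3CC[C@]2(C)C3(C)C)CC1`, gives 486000 nM.

Compound 1 and compound 2 share one core and differ by methyl in place of hydrogen on a saturated chain carbon bound to an amine nitrogen in a ring; this gives a 1.3-fold higher number from compound 1 to compound 2 (0.12 log units; within the scatter). Compound 3 sits on another core; the difference between the two cores is not broken down here. Compound 3 gives the highest number of the three, beyond the scatter against both compound 1 and compound 2.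

Compound 4, `CCN1CCN(CCC(=O)N[C@@H]2C[C@H]3CC[C@]2(C)C3(C)C)CC1`, is not yet measured. It differs from compound 3 by methyl in place of hydrogen on a saturated chain carbon bound to an amine nitrogen in a ring, the same change as from compound 1 to compound 2, at the same place. In this assay the step from compound 3 to compound 4 is expected to be small, a 1.2-fold higher number from compound 3 to compound 4 (0.09 log units; within the scatter), because the earlier step was a 1.3-fold higher number from compound 1 to compound 2 (0.12 log units; within the scatter). Compound 4 is therefore expected to give 600000 nM, estimated between 250000 nM and 1500000 nM.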

Compound 4, half-maximal cytotoxic concentration: 565000 nM
For compound 4 the middle estimate is 1.1-fold (0.03 log units) above the measured one, within the range that was stated.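

In this assay the ethyl in place of methyl on the amine nitrogen in the ring gives a 1.2-fold higher number from compound 3 to compound 4 (0.07 log units; within the scatter). The change carries from the core of compound 1 to the core of compound 3 with no difference that can be told apart: the same change on two cores in this assay, a 1.3-fold higher number (0.12 log units; within the scatter) from compound 1 to compound 2 and a 1.2-fold higher number (0.07 log units; within the scatter) from compound 3 to compound 4, 1.1-fold (0.06 log units) apart, within the scatter of two such steps. This rests on two pairs only, with both steps within the scatter, and it shows nothing about other cores or about other read-outs.

The compounds shown leave open whether a longer chain at this place, such as propyl or butyl, would also stay within the scatter on these two cores. From the compounds shown here alone, a chain ending in a hydroxyl group or a carboxylic acid is likewise open.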